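Changing the Ring on the Carbonyl Carbon

The source may report more compounds than this note shows. Statements on the series, on what has been measured and on what is new or still open speak of the compounds shown alone.

Going by the values given here, compound 1 `COc1cc2ncnc(Nc3ccc(NC(=O)c4ccccc4C)cc3)c2cc1OC` is the only compound here with a numbered result: in a functional assay on HepG2 cells (Homo sapiens) for inhibition, read by MTT assay (on this read-out lower numbers stand for stronger inhibition and higher numbers for weaker inhibition), compound 1 gives 15000 nM. Compound 2 `COc1cc2ncnc(Nc3ccc(NC(=O)c4ccccc4OC)cc3)c2cc1OC` reaches only a limit of this assay, > 100000 nM. Among the compounds with values here, the single measured step, an at least 6.6-fold higher number from compound 1 to compound 2 (0.82 log units; beyond the scatter), rests on the limit of > 100000 nM in this assay, at which 1 of the 2 values shown sits, and concerns a different change than the one followed here. Compound 3 `COc1cc2ncnc(Nc3ccc(NC(=O)c4cccc(Cl)c4)cc3)c2cc1OC` differs from compound 1 by 3-chlorophenyl in place of 2-methylphenyl on a carbonyl carbon. Within the data shown here, no measured step covers this exact exchange, so no shift beyond the scatter is expected, though with wide uncertainty. Compound 3 is therefore estimated at 15000 nM, between 4000 nM and 60000 nM, an expected step of no change at the digits printed from compound 1 to compound 3 (within the scatter).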

Compound 3, half-maximal inhibitory concentration: 12000 nM
Estimate against measurement, compound 3: 1.3-fold (0.10 log units) above; the range from low to high includes it.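

In this assay, placing 3-chlorophenyl instead of 2-methylphenyl on the carbonyl carbon gives a 1.3-fold lower number from compound 1 to compound 3 (0.10 log units; within the scatter), so these two different rings cannot be told apart at this position. The step of an at least 8.3-fold lower number from compound 2 to compound 3 (0.92 log units; beyond the scatter) shows that 3-chlorophenyl and 2-methoxyphenyl, by contrast, do separate here. That step has an open end, since the value of compound 2 is a limit: the limit of > 100000 nM in this assay, at which 1 of the 3 values shown sits.

Still open, as far as these compounds go, is how a ring carrying an amine or a carboxylic acid, or a longer chain in place of the ring, would read in this assay.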